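Trimethoxyphenyl Out, Hydroxyphenyl In, on One Core

The source may report more compounds than this note shows. Statements on the series, on what has been measured and on what is new or still open speak of the compounds shown alone.

Going by the values given here, compound 1 `CCN(CC)CCCn1c(=O)c(=Cc2cc(OC)c(OC)c(OC)c2)s/c1=C1\C(=O)Nc2ccc(C)cc21` and compound 2 `CCN(CC)CCCn1c(=O)c(=Cc2ccc(F)cc2F)s/c1=C1\C(=O)Nc2cc(F)ccc21` share the same core but differ from each other at more than one place, so no single step links them. In a functional assay on MDA-MB-231 cells (Homo sapiens) for inhibition, read by MTT assay, with a stated time of 72 h (a higher number here means a weaker inhibitor, a lower number a stronger inhibitor), compound 1 gives only a limit, > 200000 nM, and no number stands for it. In this assay compound 2 gives 2100 nM. What the two values show is that compound 1 sits at the limit, (the limit of > 200000 nM in this assay, at which 1 of the 2 values shown sits), while compound 2 returns a measured number.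

Compound 3 `CCN(CC)CCCn1c(=O)c(=Cc2ccccc2O)s/c1=C1\C(=O)Nc2ccc(C)cc21` has not yet been measured. It differs from compound 1 in one place: 2-hydroxyphenyl in place of 3,4,5-trimethoxyphenyl on a double-bonded chain carbon bound to an aromatic carbon. Among the compounds with values here, no measured pair shows this change, and because compound 1 stands only at > 200000 nM the step to compound 3 cannot be set against a measured number. The expectation is a change toward a measured value, of moderate size in the direction of stronger inhibition, with a real chance that compound 3 also returns only a limit. The step expected is an at least 3.3-fold lower number from compound 1 to compound 3 (0.52 log units; beyond the scatter). Compound 3 is therefore estimated at 60000 nM, between 5000 nM and 200000 nM.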

Compound 3, half-maximal inhibitory concentration: 15900 nM
Compound 3: the middle estimate sits 3.8-fold (0.58 log units) above what was measured, and the stated range covers the measured number.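

On the shared core, the aryl group on the double-bonded chain carbon bound to an aromatic carbon proves decisive in this assay: 2-hydroxyphenyl in place of 3,4,5-trimethoxyphenyl gives an at least 12-fold lower number from compound 1 to compound 3 (1.09 log units; beyond the scatter), a large change from this single replacement. That step gives only the smallest possible size of the change, because compound 1 stands at a limit of the assay and not at a measured number: the limit of > 200000 nM in this assay, at which 1 of the 3 values shown sits. With the rest of the molecule unchanged, compound 3 gives 15900 nM in this assay, a measured number.

The single step removes three methoxy groups and brings in one hydroxyl group together, so the compounds shown do not tell whether the gain comes from losing the former or from gaining the latter, and a plain phenyl or a 2-methoxyphenyl group at this place would be needed to separate the two. Compound 2 differs from compound 1 and compound 3 in more than one place, so it cannot settle the question.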